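Piperidine for methylpiperazine on the shared core

A few compounds are considered here, and "the series" means these few. Any claim that something is new, unique, unknown or untested is made for them only; others in the source may bear on it.

Measured in an assay on cells for displacement of a labelled ligand from adenosine receptor A2b (Homo sapiens), read by scintillation counting and radioligand binding, with a stated time of 30 min, tested at 10 uM; a higher number here means more inhibition at the concentration tested (going by the name of the read-out), a lower number less inhibition:
compound 1 `CN1CCN(c2nc(-c3cccc(Cl)c3)nc3[nH]cnc23)CC1`: 29.9%
compound 2 `CN1CCN(c2nc(-c3cccc(O)c3)nc3[nH]cnc23)CC1`: 27%

Going by the values given here, compound 1 stands highest of the two numbers, yet the only measured step, a number 2.9 percentage points lower from compound 1 to compound 2 (within the scatter), does not leave the scatter. Compound 3 `Clc1cccc(-c2nc(N3CCCCC3)c3nc[nH]c3n2)c1` differs from compound 1 at another place: piperidin-1-yl in place of 4-methylpiperazin-1-yl on an aromatic carbon. Among the compounds with values here, no measured step touches this exchange of one saturated ring for another; the step from chloro to hydroxy concerns a different position and is anyway within the scatter. For this assay, therefore, no step beyond the scatter is expected, a number 0.1 percentage points higher from compound 1 to compound 3 (within the scatter). Compound 3 is estimated at 30%, in the range 10% to 50%.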

Compound 3, a percentage reported as inhibition, at one concentration (the size of the read-out at that concentration, not a potency): > 80%
Compound 3 ended at the assay's limit; the forecaster's own chance of this, stated with the estimate: 0%; middle value at least 50 percentage points away from the limit.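

Exchanging 4-methylpiperazin-1-yl for piperidin-1-yl on the aromatic carbon next to the ring nitrogen gives a number at least 50.1 percentage points higher from compound 1 to compound 3 (beyond the scatter) in this assay. This position therefore responds strongly to the ring exchange, whereas the change from chloro to hydroxy stayed within the scatter. The value of compound 3 is a limit and not a number: the limit of > 80% in this assay, at which 1 of the 3 values shown sits.

Whether the ring nitrogen or its methyl accounts for the step stays open; morpholin-4-yl or an unsubstituted piperazin-1-yl at this place would separate the two. Also open, from the compounds shown here alone, is whether piperidin-1-yl keeps this response with hydroxy in place of chloro.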